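This account rests on a few compounds, and the source may have more. Where it says the series, first, only, none or still open, it means among the compounds named here.

Compound 2 `Cc1ccc(Nc2nc(C)c(C(=O)/C=C/c3ccccc3Cl)s2)cc1` was examined in a functional assay on NCI-H460 cells (Homo sapiens) for cytotoxicity, read by MTT assay (on this read-out lower numbers stand for stronger inhibition and higher numbers for weaker inhibition), where compound 2 gives > 25000 nM, a limit of the assay rather than a number. Compound 1 `COc1cccc(/C=C/C(=O)c2sc(Nc3ccccc3)nc2C)c1` was run in this assay as well; there compound 1 gives > 25000 nM, likewise a limit. Within the data shown here, compound 2 therefore sits where the only other value shown also sits, namely (the limit of > 25000 nM in this assay, at which 2 of the 2 values shown sit). Compound 3 `COc1cccc(/C=C/C(=O)c2sc(Nc3ccc(C)cc3)nc2C)c1` differs from compound 2 by 3-methoxyphenyl in place of 2-chlorophenyl on a double-bonded chain carbon bound to a double-bonded chain carbon. Among the measured compounds shown here, no measured step exists for such a change, so the expected step is a step that the limit leaves unreadable from compound 2 to compound 3, nothing beyond the scatter. Compound 3 is accordingly estimated at 30000 nM, with a range from 10000 nM to 100000 nM.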

Compound 3, half-maximal inhibitory concentration: > 25000 nM
Compound 3 was reported as a limit; the forecaster's own chance of this, stated with the estimate: 85%; the middle value does not contradict the limit.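

Among these compounds, no step from compound 1 or compound 2 to compound 3 can be read, since all three compounds stand at one limit: the limit of > 25000 nM in this assay, at which 3 of the 3 values shown sit.

In this assay the compounds shown leave open whether either change makes any difference to inhibition.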